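The source may hold more compounds than are shown below. What is called first, only, known or untested is meant among the compounds shown, and "the series" means these compounds.

Compound 3 `N#CSc1c(-c2ccc(Cl)cc2Cl)nc2sc(Cc3ccc(Cl)cc3)nn12` stands at the lowest of the two numbers shown in a functional assay on HeLa cells (Homo sapiens) for cytotoxicity, with a stated time of 72 h (on this read-out lower numbers stand for stronger inhibition and higher numbers for weaker inhibition), where compound 3 gives 18000 nM. Its nearest neighbour is compound 2 `Cc1ccc(-c2nc3sc(Cc4ccc(Cl)cc4)nn3c2SC#N)cc1`, which in this assay gives 22000 nM; the step of a 1.2-fold lower number from compound 2 to compound 3 (0.09 log units; within the scatter) sits within the scatter. Compound 1 `O=[N+]([O-])c1ccc(-c2cn3nc(Cc4ccc(Cl)cc4)sc3n2)cc1` in this assay gives only a limit, > 250000 nM, not a number (the limit of > 250000 nM in this assay, at which 1 of the 3 values shown sits).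

Compound 4 `N#CSc1c(-c2ccc([N+](=O)[O-])cc2)nc2sc(Cc3ccc(Cl)cc3)nn12` differs from compound 3 in one place: 4-nitrophenyl in place of 2,4-dichlorophenyl on an aromatic carbon. For the measured compounds named here, the only measured step that swaps this aryl group is the one from compound 2 to compound 3, and it stayed within the scatter. Going by the values given here, compound 1 also carries a 4-nitrophenyl group but differs from compound 3 in a second place as well, so no single step links them, and its reading is a limit rather than a number. Given the small measured step, the step of a 1.9-fold higher number from compound 3 to compound 4 (0.29 log units; within the scatter) is expected to be modest, with some risk of a weaker result. Compound 4 is estimated to give 35000 nM in this assay, within a range from 10000 nM to 150000 nM.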

Compound 4, half-maximal inhibitory concentration: 16000 nM
Estimate against measurement, compound 4: 2.2-fold (0.34 log units) above; the range from low to high includes it.
By their numbers in this assay, from the lowest: compounds 4, 3 and 2 (each within the scatter of the next). At a limit, above all of these: compound 1.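

The aryl group on this aromatic carbon now comes in three forms, 4-methylphenyl, 2,4-dichlorophenyl and 4-nitrophenyl, and this assay does not separate them: a 1.1-fold lower number from compound 3 to compound 4 (0.05 log units; within the scatter) and a 1.4-fold lower number from compound 2 to compound 4 (0.14 log units; within the scatter) are both within the scatter. Compound 1 gives only a limit, not a number: the limit of > 250000 nM in this assay, at which 1 of the 4 values shown sits. It carries the same 4-nitrophenyl group as compound 4, so this pair holds the aryl group fixed and isolates the cyanosulfanyl group, which replaces hydrogen on an aromatic carbon, and the result is an at least 15-fold lower number from compound 1 to compound 4 (1.19 log units; beyond the scatter).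

On these data alone, whether a phenyl ring bearing an amine or a carboxylic acid, or a longer alkyl chain in place of the aryl group, would also leave the number unchanged stays open. For the compounds shown here, with only this one pair, it is also open whether the large cyanosulfanyl step holds with the other aryl groups.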